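The source may hold more compounds than are shown below. What is called first, only, known or untested is meant among the compounds shown, and "the series" means these compounds.

Measured compounds:
compound 1 `Cc1cccc(-c2nc(C)c(COc3ccc4c(c3)OCC4CC(=O)O)s2)c1`, 119 nM;
compound 2 `Cc1ccc(-c2nc(C)c(COc3ccc4c(c3)OCC4CC(=O)O)s2)cc1`, 73.5 nM;
compound 3 `Cc1nc(-c2cccc(Cl)c2)sc1COc1ccc2c(c1)OCC2CC(=O)O`, 138 nM.

All three were tested in a functional assay on CHO cells for agonist activity at Free fatty acid receptor 1 (Homo sapiens), read by FLIPR and calcium flux; on this read-out higher numbers stand for an effect only at larger amounts of compound and lower numbers for an effect already at smaller amounts. Compound 3 gives the highest number of the three, but the steps of a 1.2-fold higher number from compound 1 to compound 3 (0.06 log units; within the scatter) and of a 1.9-fold higher number from compound 2 to compound 3 (0.27 log units; within the scatter) both lie within the scatter, so no order can be claimed among them. The unmeasured compound 4 `COc1ccc(-c2nc(C)c(COc3ccc4c(c3)OCC4CC(=O)O)s2)cc1` differs from compound 3 by one change: 4-methoxyphenyl in place of 3-chlorophenyl on an aromatic carbon. Going by the values given here, two measured steps bear on it. The move from 3-methylphenyl to 4-methylphenyl gave a 1.6-fold lower number from compound 1 to compound 2 (0.21 log units; within the scatter), and the move from 4-methylphenyl to 3-chlorophenyl gave a 1.9-fold higher number from compound 2 to compound 3 (0.27 log units; within the scatter); both are within the scatter. Among the compounds with values here, no measured compound carries a methoxy group, so that part of the change is untested. On this basis compound 4 is expected to sit close to compound 2, with a step of a 1.6-fold lower number from compound 3 to compound 4 (0.21 log units; within the scatter) that need not exceed the scatter. Compound 4 is therefore estimated at 85 nM in this assay, within a range of 35 nM to 210 nM.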

Compound 4, half-maximal effective concentration: 123 nM
For compound 4 the middle estimate is 1.4-fold (0.16 log units) below the measured one, within the range that was stated.
By their numbers in this assay, from the lowest: compounds 2, 1, 4 and 3 (each within the scatter of the next).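

In this assay the place on the five-membered ring now holds 4-methoxyphenyl, which brings an oxygen and a hydrogen-bond acceptor that the earlier aryl groups lack, yet all three new steps lie within the scatter: a 1.1-fold lower number from compound 3 to compound 4 (0.05 log units; within the scatter) and a 1.7-fold higher number from compound 2 to compound 4 (0.22 log units; within the scatter) and a 1.0-fold higher number from compound 1 to compound 4 (0.01 log units; within the scatter). Going by these compounds alone, the earlier compounds covered only methyl and chloro on the phenyl ring, so this is the first sign that a methoxy group there also leaves the number within the scatter of those compounds, and the four cannot be ordered. Nothing available gives a reason for this.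

As far as these compounds go, whether 3-methoxyphenyl would behave like 4-methoxyphenyl remains open. So does whether an amine, a carboxylic acid or a longer chain such as butoxy on the phenyl ring would give a step beyond the scatter.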